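Chloro in place of ethyl on the aryl carbamate

The compounds below may be only part of what the source reports. "The series", "measured", "known", "first", "only" and "open" are said of these compounds alone.

Compound 1 `C=C1C(=O)OC[C@@H]1CCOC(=O)Nc1ccc(Br)cc1`: 720 nM
Compound 2 `C=C1C(=O)OC[C@H]1CCOC(=O)Nc1c(C)cccc1C(C)C`: 1940 nM
Compound 3 `C=C1C(=O)OC[C@@H]1CCOC(=O)Nc1ccc(CC)cc1`: 1260 nM

In a functional assay on RAW264.7 cells (Mus musculus) for inhibition, with a stated time of 30 min (a lower number here means a stronger inhibitor, a higher number a weaker inhibitor), compound 3 holds the second highest of the three numbers. For the measured compounds named here, its nearest neighbour is compound 2; its furthest is compound 1, and that gap is the single one-place step known here, a 1.8-fold higher number from compound 1 to compound 3 (0.24 log units; within the scatter), which replaced bromo by ethyl on an aromatic carbon.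

Compound 4 `C=C1C(=O)OC[C@@H]1CCOC(=O)Nc1ccc(Cl)cc1` differs from compound 3 by chloro in place of ethyl on an aromatic carbon. The step of a 1.8-fold higher number from compound 1 to compound 3 (0.24 log units; within the scatter) is the only one that bears on this change, as it likewise exchanged a halogen and ethyl at that aromatic carbon, and it stayed within the scatter. Compound 4 is therefore expected to land near compound 1, with a step of a 1.6-fold lower number from compound 3 to compound 4 (0.20 log units; within the scatter) that does not clear the scatter. The estimate for compound 4 is 800 nM, between 400 nM and 1600 nM.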

Compound 4, half-maximal inhibitory concentration: 1070 nM
Compound 4: middle estimate off by 1.3-fold (0.13 log units), on the low side, within the range that was stated.
By their numbers in this assay, from the lowest: compounds 1, 4, 3 and 2 (each within the scatter of the next, the first and the last beyond it).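

In this assay, swapping ethyl for chloro at the aromatic carbon para to a large group gives a 1.2-fold lower number from compound 3 to compound 4 (0.07 log units; within the scatter), and chloro in place of bromo gives a 1.5-fold higher number from compound 1 to compound 4 (0.17 log units; within the scatter), so both steps stay within the scatter. Together with the earlier step from bromo to ethyl, this places chloro, bromo and ethyl at this position within the scatter of one another.

As far as these compounds go, whether an amine, a carboxylic acid or a longer chain at this carbon would move the number beyond the scatter remains open. Nothing available explains these small differences.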